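The compounds below may be only part of what the source reports. "The series", "measured", "known", "first", "only" and "open" are said of these compounds alone.

Measured compounds:
compound 1, `Cn1cccc1-c1cc(-c2cccs2)nc(N)c1C#N`: > 100000 nM
compound 2, `Cn1cccc1-c1cc(-c2cccs2)[nH]c(=O)c1C#N`: 25700 nM
compound 3, `Cn1cccc1-c1cc(-c2ccccc2)[nH]c(=O)c1C#N`: > 100000 nM

In a functional assay on NCI-H522 cells (Homo sapiens) for inhibition, read by sulforhodamine B assay, with a stated time of 48 h (a lower number here means a stronger inhibitor of growth, a higher number a weaker inhibitor of growth), compound 1 returns only a limit of the assay, > 100000 nM. Compound 2, in this assay, gives a measured number, 25700 nM. Compound 3 in this assay likewise returns only a limit, > 100000 nM. The cores of compound 1 and compound 2 differ in more than one place, and that difference is not broken down here.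

One structural change recurs twice in the set. From compound 2 to compound 3 it is phenyl in place of thiophen-2-yl on an aromatic carbon, and it makes the step of an at least 3.8-fold higher number from compound 2 to compound 3 (0.59 log units; beyond the scatter). The unmeasured compound 4, `Cn1cccc1-c1cc(-c2ccccc2)nc(N)c1C#N`, carries the same kind of change relative to compound 1: phenyl in place of thiophen-2-yl on an aromatic carbon. The surroundings are not identical word for word: in the change from compound 2 to compound 3 the place is meta to a group of 1 heavy atom, whereas in the change from compound 1 to compound 4 it is meta to an amino group.

Compound 1 already sits at the limit of > 100000 nM in this assay, at which 2 of the 3 values shown sit, as does compound 3. Given the direction seen from compound 2 to compound 3, the expected step that the limit leaves unreadable from compound 1 to compound 4 cannot be resolved by the assay and compound 4 is expected to stay at the limit. Compound 4 is therefore estimated at 150000 nM, between 80000 nM and 400000 nM, most likely reported only as a limit.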

Compound 4, concentration for 50% growth inhibition: 61600 nM
Compound 4: the middle estimate sits 2.4-fold (0.39 log units) above what was measured; measured number outside the range, below it.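

In this assay, phenyl in place of thiophen-2-yl gives an at least 1.6-fold lower number from compound 1 to compound 4 (0.21 log units; that floor lies within the scatter), and this step differs from the one seen earlier for the same change on the other core: the same change on two cores in this assay, an at least 3.8-fold higher number (0.59 log units; beyond the scatter) from compound 2 to compound 3 and an at least 1.6-fold lower number (0.21 log units; that floor lies within the scatter) from compound 1 to compound 4, at least 6.3-fold (0.80 log units) apart, beyond the scatter of two such steps. The effect of this change therefore does not carry over unchanged between these two cores, so a step measured on one core gives no safe estimate of the step on the other. This comparison does not give the true size of either step, nor does it identify which difference between the two cores is responsible, and each step has a limit of the assay at one end: the limit of > 100000 nM in this assay, at which 2 of the 4 values shown sit.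

The compounds shown cover only two groups at this place, so it remains open whether the difference between the cores also appears with furan-2-yl, pyridin-3-yl or a 4-methoxyphenyl group. Also open, as far as these compounds go, is how the series responds when the amino group gives way to a methylamino or acetamido group, or when the nitrile gives way to a carboxamide or a carboxylic acid.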